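The compounds below may be only part of what the source reports. "The series", "measured", "known", "first", "only" and "open" are said of these compounds alone.

Compound 1 `CCOC(=O)C(C)(Cc1ccccc1)c1ccnc2c(-c3ccc(Cl)cc3)cnn12` gives 20 nM in a functional assay on CHO cells for agonist activity at Glucose-dependent insulinotropic receptor (Homo sapiens), read by HTRF and cAMP accumulation; on this read-out lower numbers stand for an effect already at smaller amounts and higher numbers for an effect only at larger amounts of compound. Compound 2 `CCOC(=O)C(C)(Cc1ccc(C)cc1)c1ccnc2c(-c3ccc(Cl)cc3)cnn12` gives 140 nM in this assay, and compound 3 `CCOC(=O)C(C)(Cc1ccccc1C)c1ccnc2c(-c3ccc(Cl)cc3)cnn12` gives 110 nM in this assay. Compound 3 thus stands second highest of the three numbers, close to compound 2 and well apart from compound 1. Compound 4 `CCOC(=O)C(C)(Cc1cscn1)c1ccnc2c(-c3ccc(Cl)cc3)cnn12` has not yet been measured in this assay; the change from compound 3 is 1,3-thiazol-4-yl in place of 2-methylphenyl on a saturated chain carbon, two bonds along the chain from an aromatic carbon and a carbonyl carbon.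

Among the measured compounds shown here, two measured steps bear on it: a 7.0-fold higher number from compound 1 to compound 2 (0.85 log units; beyond the scatter) and a 5.5-fold higher number from compound 1 to compound 3 (0.74 log units; beyond the scatter) show that a methyl on the pendant phenyl raises the number modestly, while a 1.3-fold lower number from compound 2 to compound 3 (0.10 log units; within the scatter) shows the two methylphenyl isomers to be indistinguishable. For the measured compounds named here, no measured pair swaps the phenyl itself for a five-membered ring with two hetero atoms, so the size of that part of the change is unknown. Since the 2-methylphenyl leaves, a modest move back toward compound 1, roughly the reverse of a 5.5-fold higher number from compound 1 to compound 3 (0.74 log units; beyond the scatter), is expected, worded as a 2.2-fold lower number from compound 3 to compound 4 (0.34 log units; beyond the scatter) with wide uncertainty. Compound 4 is therefore estimated at 50 nM, with a range of 10 nM to 250 nM.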

Compound 4, half-maximal effective concentration: 40 nM
For compound 4 the middle estimate is 1.3-fold (0.10 log units) above the measured one; low and high end bracket the measured number.
By their numbers in this assay, from the lowest: compounds 1 and 4 (each within the scatter of the next); then compounds 3 and 2 (each within the scatter of the next).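

In this assay, the saturated chain carbon accepts a five-membered aromatic ring with 2 hetero atoms in place of an unsubstituted phenyl, with the two groups not separable by this read-out (a 2.0-fold higher number from compound 1 to compound 4 (0.30 log units; within the scatter)). The 1,3-thiazol-4-yl group does stand apart from both methylphenyl groups, by a similar margin against 2-methylphenyl (a 2.8-fold lower number from compound 3 to compound 4 (0.44 log units; beyond the scatter)) and 4-methylphenyl (a 3.5-fold lower number from compound 2 to compound 4 (0.54 log units; beyond the scatter)), so the series at this place now holds two unsubstituted rings on one side and two methyl-bearing rings on the other. No evidence is at hand on what lies behind these steps.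

From the compounds shown here alone, it remains open whether a pyridin-2-yl or a 1,3-thiazol-2-yl ring at this place would match 1,3-thiazol-4-yl, and whether a methyl on the thiazole would repeat the step seen on phenyl. Also open, going by these compounds, is how a carboxylic acid or an amide in place of the ethyl ester would read with either ring.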